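The source may report more compounds than this note shows. Statements on the series, on what has been measured and on what is new or still open speak of the compounds shown alone.

Measured compounds:
compound 1 `COc1ncnc2c1c(-c1ccsc1)cn2[C@@H]1O[C@H](CO)[C@@H](O)[C@H]1O` — in a functional assay on A549 cells (Homo sapiens), read by MTT assay, with a stated time of 72 h (on this read-out higher numbers stand for weaker inhibition and lower numbers for stronger inhibition), compound 1 gives 5170 nM
compound 2 `COc1ncnc2c1c(-c1ccoc1)cn2[C@@H]1O[C@H](CO)[C@@H](O)[C@H]1O` — in this assay compound 2 gives 1160 nM

Compound 2 stands lowest of the two numbers; its nearest neighbour is compound 1, separated by a 4.5-fold lower number from compound 1 to compound 2 (0.65 log units; beyond the scatter), which rests on furan-3-yl in place of thiophen-3-yl on an aromatic carbon.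

Compound 3 `Cc1ncnc2c1c(-c1ccoc1)cn2[C@@H]1O[C@H](CO)[C@@H](O)[C@H]1O` is not yet measured. It differs from compound 2 by methyl in place of methoxy on an aromatic carbon. For the measured compounds named here, the single measured step, a 4.5-fold lower number from compound 1 to compound 2 (0.65 log units; beyond the scatter), concerns the five-membered ring and says nothing about the methoxy, so no measured step bears on the present change. The direction of the step in this assay is therefore open, and the estimate is kept close to compound 2 with a wide range, allowing either a modest step or none beyond the scatter. Compound 3 is expected to give about 2500 nM, with a range from 700 nM to 9000 nM, which means an expected step of a 2.2-fold higher number from compound 2 to compound 3 (0.33 log units; beyond the scatter).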

Compound 3, half-maximal inhibitory concentration: > 20000 nM
Compound 3 gave a limit, no number; the forecaster's own chance of this, stated with the estimate: 5%; middle value at least 8.0-fold (0.90 log units) away from the limit.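

In this assay, methyl in place of methoxy on an aromatic carbon gives an at least 17-fold higher number from compound 2 to compound 3 (1.23 log units; beyond the scatter), so the group at this position bears strongly on the read-out, which the earlier step on the five-membered ring, a 4.5-fold lower number from compound 1 to compound 2 (0.65 log units; beyond the scatter), could not show. Compound 3 gives > 20000 nM, which is a limit of the assay and not a number. The step from the methoxy compound therefore has a lower bound only, and its true size stays unknown: the limit of > 20000 nM in this assay, at which 1 of the 3 values shown sits.

With only methoxy and methyl shown at this position, it remains open whether an amine, a hydroxyl or a longer chain such as ethoxy would keep the number near that of compound 2. As far as these compounds go, it is also open whether the step between thiophen-3-yl and furan-3-yl would carry over to a core bearing methyl.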